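Removing the chloro from an acylhydrazone

The source may hold more compounds than are shown below. What is called first, only, known or untested is meant among the compounds shown, and "the series" means these compounds.

Measured in a functional assay on COLO 205 cells (Homo sapiens) for antiproliferative activity, read by sulforhodamine B assay, with a stated time of 48 h; a higher number here means a weaker inhibitor of growth, a lower number a stronger inhibitor of growth:
Compound 2 `COc1ccc(OC)c(/C=C/C(=O)N/N=C/c2ccc(Cl)cc2)c1` gives 595 nM.
Compound 1 `COc1ccc(OC)c(/C=C/c2nnc(Nc3ccc(Cl)cc3)o2)c1` gives a limit, > 100000 nM.

For the measured compounds named here, compound 2 holds the only real number in this assay; compound 1 sits at the limit of > 100000 nM in this assay, at which 1 of the 2 values shown sits, which is a limit and not a measured value. Compound 3 `COc1ccc(OC)c(/C=C/C(=O)N/N=C/c2ccccc2)c1` differs from compound 2 by hydrogen in place of chloro on an aromatic carbon. Going by the values given here, no step between measured compounds is available, so the expected size rests on the change alone: a small to moderate loss of growth inhibition, a step of a 2.5-fold higher number from compound 2 to compound 3 (0.40 log units; beyond the scatter) that may reach beyond the scatter but is not expected to be large. Compound 3 is therefore estimated at 1500 nM, in a range from 400 nM to 6000 nM.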

Compound 3, concentration for total growth inhibition: 35100 nM
Beside the measured number, compound 3's estimate is 23-fold (1.37 log units) below it, outside the stated range (above it).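

Replacing the chloro with hydrogen gives a 59-fold higher number from compound 2 to compound 3 (1.77 log units; beyond the scatter) and so shows that this one heavy atom on the aromatic ring carries much of the growth inhibition of compound 2. For the compounds shown here, this is the first step between measured compounds, and it shows that the position is far more sensitive to this change than the earlier compounds could reveal.

On these data alone, whether a bromo, a fluoro or an amine in the same place would keep the growth inhibition of compound 2 stays open. Nothing measured here gives a reason why the chloro matters so much.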